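Swapping pentyl for sec-butyl on an amide nitrogen

A few compounds are considered here, and "the series" means these few. Any claim that something is new, unique, unknown or untested is made for them only; others in the source may bear on it.

Measured in a functional assay on the whole organism for inhibition, with Brassica rapa subsp. chinensis as the target, with a stated time of 3 days, tested at 100 ppm; on this read-out higher numbers stand for more inhibition of growth at the one concentration tested and lower numbers for less inhibition of growth:
- compound 1 `CCCCCNC(=O)/C=C/c1ccccc1`: 60%
- compound 2 `CCCCCCCCNC(=O)/C=C/c1ccccc1`: 34%

Of these two compounds, compound 1 holds the higher number, at 60%. The next compound to test is compound 3 `CCC(C)NC(=O)/C=C/c1ccccc1`, and the change is sec-butyl in place of pentyl on an amide-type nitrogen. Among the measured compounds shown here, only one measured step bears on this. It is a number 26 percentage points lower from compound 1 to compound 2 (beyond the scatter), and it shows that a longer chain in this same part of the molecule can lower the number beyond the scatter. For the measured compounds named here, compound 3 goes the other way in size, and no measured compound carries sec-butyl, so this single step offers weak guidance. Only a small change, probably within the scatter, is therefore expected in this assay. The estimated change is a number 5 percentage points lower from compound 1 to compound 3 (within the scatter). For compound 3 the expected value is 55%, with an estimated range of 35% to 75%.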

Compound 3, percent growth inhibition at one concentration: 56%
Compound 3: the middle estimate sits 1 percentage points below what was measured, and the stated range covers the measured number.
By their numbers in this assay, from the lowest: compound 2; then compounds 3 and 1 (each within the scatter of the next).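

In this assay, putting sec-butyl in place of pentyl on the amide-type nitrogen gives a number 4 percentage points lower from compound 1 to compound 3 (within the scatter), so this position accepts a branched group with one carbon fewer, with no change that can be told from the scatter. Among the compounds shown here, the earlier step showed only that a longer chain here, in compound 2, can lower the number; compound 3 adds the first look at a smaller group, and it stays level with compound 1. No measurement at hand gives a cause for this result.

Sec-butyl differs from pentyl in both length and branching, so these compounds cannot separate the two. Also open, from the compounds shown here alone, is whether a straight butyl chain, a small methyl group or a cyclohexyl ring on this nitrogen would keep the number at this level.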